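A few compounds are considered here, and "the series" means these few. Any claim that something is new, unique, unknown or untested is made for them only; others in the source may bear on it.

In an ADME assay on cells (Epithelial cell, Homo sapiens) for antiproliferative activity, read by MTT assay, with a stated time of 48 h (a lower number here means a stronger inhibitor, a higher number a weaker inhibitor), compound 1 `COC(=O)/C(=C/c1ccccc1)CN1C(=O)[C@@H](OC)[C@H]1c1ccccc1C(F)(F)F` gives "not toxic" (no number reported) as its result, so it stands without a single number. The same is true of compound 2 `COC(=O)/C(=C/c1ccccc1)CN1C(=O)[C@@H](OC)[C@H]1c1cccc(Cl)c1` with "not toxic" (no number reported) as its entry. Only compound 3 `COC(=O)/C(=C/c1ccccc1)CN1C(=O)[C@@H](OC)[C@H]1c1ccc(Cl)cc1Cl` carries a figure, at 70000 nM in this small series.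

Compound 4 `COC(=O)/C(=C/c1ccccc1)CN1C(=O)[C@@H](OC)[C@H]1c1ccccc1` has yet to be measured. It keeps the core of compound 1 and differs from it in one place: hydrogen in place of trifluoromethyl on an aromatic carbon so that 2-(trifluoromethyl)phenyl becomes phenyl.

Among the compounds with values here, no pair of measured compounds differs in one place only, and compound 1 has no number to step from, so the size of this change cannot be read from the data. The expectation in this assay is therefore no step beyond the usual scatter in either direction, measured from compound 3 at 70000 nM as the sole numerical reference. There is also a real chance that this compound, like compound 1 and compound 2, returns no number at all.

For compound 4 the estimated value is 70000 nM with an expected range from 20000 nM to 200000 nM in this assay.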

Compound 4, half-maximal inhibitory concentration: "not toxic" (no number reported)
Compound 4: no number reported; no gap can be computed for the estimate.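

In this assay compound 4 gives "not toxic" (no number reported) just as compound 1 gives "not toxic" (no number reported) and so no step can be read between compound 1 and compound 4. Nothing shown here bears on this result. The compounds shown leave open what replacing trifluoromethyl with hydrogen does to the activity in this series.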